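Adding methoxy to the phenyl ring of compound 1

The compounds below may be only part of what the source reports. "The series", "measured", "known", "first", "only" and "open" are said of these compounds alone.

Measured so far in a functional assay on HeLa cells (Homo sapiens) for antiproliferative activity, read by MTT assay, with a stated time of 48 h; a lower number here means a stronger inhibitor, a higher number a weaker inhibitor:
- compound 1 `Cc1ccc2[nH]c(-c3cn(-c4ccccc4)nc3-c3ccccc3)nc2c1` with 6560 nM
- compound 2 `Cc1cc2nc(-c3cn(-c4ccccc4)nc3-c3ccccc3)[nH]c2cc1C` with 41500 nM
- compound 3 `O=C(OCc1ccccc1)c1ccc2[nH]c(-c3cn(-c4ccccc4)nc3-c3ccccc3)nc2c1` with 21300 nM

Compound 1 has the lowest number of these three, so it is the strongest inhibitor of the set. Compound 4 `COc1ccc(-c2nn(-c3ccccc3)cc2-c2nc3cc(C)ccc3[nH]2)cc1` is still unmeasured. It keeps the core of compound 1 but carries 4-methoxyphenyl where compound 1 has phenyl, with methoxy in place of hydrogen on an aromatic carbon, para to a large group: methoxy in place of hydrogen on an aromatic carbon sums up the difference.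

Within the data shown here, no measured step adds methoxy or alters this ring, so the evidence is indirect. The two available changes lie elsewhere on the core, and both raised the number modestly: a 3.2-fold higher number from compound 1 to compound 3 (0.51 log units; beyond the scatter) and a 6.3-fold higher number from compound 1 to compound 2 (0.80 log units; beyond the scatter) are the steps in question. On that slender basis, a small upward move is expected in this assay, perhaps not beyond the scatter. The estimated change is a 1.5-fold higher number from compound 1 to compound 4 (0.18 log units; within the scatter) for this substitution. Compound 4 is estimated at 10000 nM with an expected range of 3000 nM to 32000 nM in this test.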

Compound 4, half-maximal inhibitory concentration: 3290 nM
Estimate against measurement, compound 4: 3.0-fold (0.48 log units) above; measured number inside the range.
By their numbers in this assay, from the lowest: compounds 4 and 1 (each within the scatter of the next); then compounds 3 and 2 (each within the scatter of the next).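

In this assay, phenyl gives way to 4-methoxyphenyl with a 2.0-fold lower number from compound 1 to compound 4 (0.30 log units; within the scatter) as the first step shown that touches this ring. The two earlier steps (a 6.3-fold higher number from compound 1 to compound 2 (0.80 log units; beyond the scatter)) and (a 3.2-fold higher number from compound 1 to compound 3 (0.51 log units; beyond the scatter)) lay elsewhere on the core and went beyond the scatter, whereas methoxy on this aromatic carbon, para to a large group, leaves the two compounds within the scatter of each other, so the ring carries the added group with no measurable loss in this test. Nothing measured here offers an explanation for this result.

The compounds shown leave open whether a hydroxyl, an amine, a carboxylic acid or a longer alkoxy chain would be accepted at this same place. They also leave open whether methoxy would give a similar number elsewhere on this ring.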